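The compounds below may be only part of what the source reports. "The series", "measured", "known", "first", "only" and "open" are said of these compounds alone.

Compound 1 `C[C@]1(CN2CCc3nc(-c4ccccc4F)ccc3C2)Cn2cc([N+](=O)[O-])nc2O1`: in an ADME assay on Vero cells (Chlorocebus sabaeus) for cytotoxicity, read by MTT assay, with a stated time of 72 h (a higher number here means that more compound is tolerated, a lower number that less compound is tolerated), compound 1 gives > 32 ug/mL, a limit of the assay.
Compound 2 `C[C@]1(CN2CCc3nc(-c4ccc(Cl)c(F)c4)ccc3C2)Cn2cc([N+](=O)[O-])nc2O1`: in this assay compound 2 gives > 32 ug/mL, also a limit.

Compound 2 therefore stands at the ceiling of the measurement, where both values sit (the limit of > 32 ug/mL in this assay, at which 2 of the 2 values shown sit). The step that the two limits leave unreadable from compound 1 to compound 2 is for that reason unreadable in size. Compound 3 `C[C@]1(CN2CCc3nc(-c4cc(F)c(F)c(F)c4)ccc3C2)Cn2cc([N+](=O)[O-])nc2O1` differs from compound 2 by 3,4,5-trifluorophenyl in place of 4-chloro-3-fluorophenyl on an aromatic carbon. Among the compounds with values here, only the step from compound 1 to compound 2 bears on this change, and it yields no readable size, so no shift beyond the scatter is expected. Compound 3 is expected to give 40 ug/mL in this assay, within 20 ug/mL to 80 ug/mL. The expected step is a step that the limit leaves unreadable from compound 2 to compound 3, most likely again reported as a limit.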

Compound 3, half-maximal cytotoxic concentration: > 32 ug/mL
Compound 3 gave a limit, no number; the forecaster's own chance of this, stated with the estimate: 85%; the middle value does not contradict the limit.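

No new step can be read from compound 1, compound 2 or compound 3, since each value is only a limit: the limit of > 32 ug/mL in this assay, at which 3 of the 3 values shown sit. As far as these compounds go, how far each compound's true value lies beyond that limit, and whether these ring changes alter it, remains open.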